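Working notes: hydrogen in place of acetoxy

This account rests on a few compounds, and the source may have more. Where it says the series, first, only, none or still open, it means among the compounds named here.

Measured in a functional assay on HEp-2 cells (Homo sapiens) for cytotoxicity, read by MTT assay; on this read-out lower numbers stand for an effect already at smaller amounts and higher numbers for an effect only at larger amounts of compound:
- compound 1 (`C=C1C(=O)O[C@@H]2[C@@H]1C[C@H](O)[C@@]1(C)CC[C@@H](O1)C(=C)CC/C=C(\C)[C@@H]2OC(C)=O`): 6.2 ug/mL
- compound 2 (`C=C1CC/C=C(\C)[C@H](OC(C)=O)[C@@H]2OC(=O)C(=C)[C@H]2C[C@H](O)[C@@]2(C)CC[C@@H]1O2`): 4.5 ug/mL

Among the measured compounds shown here, on these numbers compound 1 cannot be separated from compound 2, as the only measured step shows: a 1.4-fold lower number from compound 1 to compound 2 (0.14 log units; within the scatter). That step concerns configuration alone (the fact that compounds 1 and 2 differ only in the configuration as drawn).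

Compound 3 (`C=C1C(=O)O[C@H]2C/C(C)=C/CCC(=C)[C@H]3CC[C@@](C)(O3)[C@@H](O)C[C@H]12`) differs from compound 1 by hydrogen in place of acetoxy on a saturated ring carbon. For the measured compounds named here, no measured step touches the acetoxy group, so the series gives no direct size or direction for this change. The step in compound 1 to compound 2 serves only as a measure of how close two values can lie in this assay. No shift beyond the scatter is therefore expected, and no direction is favoured, though with little confidence. The estimated step is a 1.0-fold lower number from compound 1 to compound 3 (0.01 log units; within the scatter) as a central expectation. The expected value for compound 3 is 6 ug/mL with an estimated range from 2 ug/mL to 18 ug/mL as a deliberately wide span.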

Compound 3, concentration for half-maximal effect: 2.6 ug/mL
Beside the measured number, compound 3's estimate is 2.3-fold (0.36 log units) above it; measured number inside the range.
By their numbers in this assay, from the lowest: compounds 3, 2 and 1 (each within the scatter of the next, the first and the last beyond it).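

Hydrogen in place of acetoxy on a saturated ring carbon gives a 2.4-fold lower number from compound 1 to compound 3 (0.38 log units; beyond the scatter) in this assay, the first step in the series that lies beyond the scatter, though a modest one. The acetoxy group is therefore not required for the cytotoxic effect in this assay, and on this pair its loss moves the number down rather than up. Nothing shown on the series accounts for the size or direction of this step.

From the compounds shown here alone, it remains open whether the shift reflects the loss of acetoxy as such or would also appear with other groups on this carbon, such as an amine or a longer ester chain. Going by these compounds, whether the configuration change seen in compound 2 would have any effect without the acetoxy group also remains open.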